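The source may report more compounds than this note shows. Statements on the series, on what has been measured and on what is new or still open speak of the compounds shown alone.

Compound 1 `O=C1CC(c2c(-c3ccc[nH]3)[nH]c3ccccc23)C(=O)N1` gives 4000 nM in the first measurement.
Compound 2 `Cc1ccc2[nH]c(-n3cccn3)c(C3=C(Br)C(=O)NC3=O)c2c1` gives 27000 nM in the second.
Compound 3 `COc1ccc2[nH]c3c4cn[nH]c4c4c(c3c2c1)C(=O)NC4=O` gives 51000 nM in the third.

In a functional assay on U-373MG ATCC cells (Homo sapiens) for cytotoxicity, read by MTT assay, with a stated time of 72 h (on this read-out higher numbers stand for weaker inhibition and lower numbers for stronger inhibition), compound 3 reads 51000 nM and compound 2 reads 27000 nM, two numbers within the scatter of each other, and together they stand at the high end of the three. Compound 1, at 4000 nM, has a clearly lower number than compound 3, a gap beyond the scatter.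

Compound 4 `Cc1ccc2[nH]c3c4cn[nH]c4c4c(c3c2c1)C(=O)NC4=O` has not yet been measured. It carries methyl in place of methoxy on an aromatic carbon and otherwise matches compound 3. For the measured compounds named here, no two measured compounds differ in one place only, so the data hold no direct precedent for this change. With nothing to suggest a large effect, the expectation in this assay is no step beyond the scatter, with at most a slight drift towards a lower number. The expected change is a 1.3-fold lower number from compound 3 to compound 4 (0.11 log units; within the scatter) and so stays within the scatter. Going by the values given here, this expectation rests on compound 3 at 51000 nM as the only measured compound sharing the core of compound 4. The estimated value for compound 4 is 40000 nM, with an expected range from 13000 nM to 120000 nM as the estimate stands.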

Compound 4, half-maximal inhibitory concentration: > 100000 nM
Compound 4 was reported as a limit; the forecaster's own chance of this, stated with the estimate: 15%; middle value at least 2.5-fold (0.39 log units) away from the limit.
By their numbers in this assay, from the lowest: compound 1; then compounds 2 and 3 (each within the scatter of the next). At a limit, above all of these: compound 4.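

In this assay compound 4 gives > 100000 nM, which is a limit of the assay and not a number. For the compounds shown here, this is the first one-place comparison, and it concerns an aromatic carbon of a six-membered aromatic ring of carbon only, part of a fused or bridged system of five rings: methyl in place of methoxy gives an at least 1.9-fold higher number from compound 3 to compound 4 (0.29 log units; that floor lies within the scatter), so the change shows no move towards a lower number, although the floor of the step alone does not establish a change beyond the scatter. Compound 4 is also the only compound shown that is reported in this way: the limit of > 100000 nM in this assay, at which 1 of the 4 values shown sits.

On these data alone, how far compound 4 lies past its limit stays open, so the true size of the step, and whether it exceeds the scatter, cannot be read from these compounds. Going by these compounds alone, also open is how a hydroxyl group, an amine or a chlorine on this same aromatic carbon would read on the shared core, since methoxy and methyl alone give only a single comparison at this position.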